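Half-life in the monkey after swapping one substituent on the shared core

A few compounds are considered here, and "the series" means these few. Any claim that something is new, unique, unknown or untested is made for them only; others in the source may bear on it.

Of the compounds shown here, two have been measured in an ADME assay on the whole organism (Macaca fascicularis) for metabolic stability, read by LC-MS, using cassette dosing, at a dose of 1 mg/kg by the oral route; on this read-out higher numbers stand for a longer-lived compound and lower numbers for a shorter-lived compound. Compound 1, `C[C@H](c1ccc(-c2cc(Cl)ccc2-c2nc(=O)o[nH]2)cc1)N(CC1CC1)c1nc2c(C(=O)O)cccc2o1`, gives 0.8 h. Compound 2, `CCCCN(c1nc2c(NS(C)(=O)=O)cccc2o1)[C@H](C)c1ccc(-c2ccccc2-c2nnn[nH]2)cc1`, gives 4.7 h, the higher of the two values, and the gap between compound 2 and compound 1 is beyond the usual scatter of this assay. These two compounds differ in several places at once, so no single change can be read from their values.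

Compound 3, `CCCCN(c1nc2c(C(=O)N(C)C)cccc2o1)[C@H](C)c1ccc(-c2ccccc2-c2nnn[nH]2)cc1`, has not been measured. It differs from compound 2 in one place: dimethylcarbamoyl in place of methanesulfonamido on an aromatic carbon. Going by the values given here, no measured pair shows this exact change, so the expectation rests on compound 2 alone and carries the uncertainty of a single reference point. The step from compound 2 to compound 3 in this assay is expected to be small, a 1.3-fold lower number from compound 2 to compound 3 (0.13 log units; within the scatter), and not beyond the scatter. Compound 3 is expected to give 3.5 h, with a range from 1.4 h to 8.5 h.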

Compound 3, half-life: 3.2 h
For compound 3 the middle estimate is 1.1-fold (0.04 log units) above the measured one, and the stated range covers the measured number.
By their numbers in this assay, from the lowest: compound 1; then compounds 3 and 2 (each within the scatter of the next).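

In this assay, going by these compounds alone, the exchange of methanesulfonamido for dimethylcarbamoyl on this aromatic carbon gives a 1.5-fold lower number from compound 2 to compound 3 (0.17 log units; within the scatter) and is the first single change that can be read here. At this position, the half-life therefore does not separate the two groups, although the entering group has no hydrogen-bond donor and the leaving group has one. No measurement shown here offers an explanation for this result.

The compounds shown leave open how a primary amine or a nitrile on the same aromatic carbon would read in this assay, and whether such groups would also stay within the scatter of compound 2. They also leave open whether the exchange of these two groups would give a similar step on a core bearing a longer chain on its nitrogen.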